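Exchanging a Cyclohexyl Ketone for a Fluorinated Carbamate

This account rests on a few compounds, and the source may have more. Where it says the series, first, only, none or still open, it means among the compounds named here.

Of the compounds shown here, two have so far been measured in a functional assay on HepG2 cells (Homo sapiens) for inhibition, read by scintillation counting, with a stated time of 2 h; a lower number here means a stronger inhibitor, a higher number a weaker inhibitor. Compound 1 `CC(=O)N1CCC(C(=O)N2CCC(N3CCN(C(=O)c4cc(-c5ccc(C)cc5)nc(-c5ccc(C)cc5)c4)CC3)CC2)CC1` gives 343 nM. Compound 2 `CCNC(=O)Nc1sc2ccccc2c1C(=O)N1CCN(C2CCN(C(=O)C3CCCCC3)CC2)CC1` gives 146 nM, the lower of the two numbers; the gap between compound 2 and compound 1 lies beyond the usual scatter of repeat measurements, so compound 2 is the stronger inhibitor of the pair. Among the compounds with values here, no two measured compounds differ in only one place, so no single step has been quantified.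

Compound 3 `CCNC(=O)Nc1sc2ccccc2c1C(=O)N1CCN(C2CCN(C(=O)OC(C)(C)C(F)(F)F)CC2)CC1` keeps the whole of compound 2 apart from one change: 1-methyl-1-(trifluoromethyl)ethoxy in place of cyclohexyl on a carbonyl carbon. Cut one bond further out, the same difference reads cyclohexylcarbonyl to (1-methyl-1-(trifluoromethyl)ethoxy)carbonyl.

Within the data shown here, nothing among the measured compounds tests this kind of replacement, so the expectation rests on compound 2 alone and on the modest size of the change. Compound 3 is expected to stay close to compound 2 in this assay, with a step of a 1.7-fold higher number from compound 2 to compound 3 (0.23 log units; within the scatter) that may well fall within the scatter. Compound 3 is estimated at 250 nM, within a range of 80 nM to 800 nM.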

Compound 3, half-maximal inhibitory concentration: 81 nM
Beside the measured number, compound 3's estimate is 3.1-fold (0.49 log units) above it; the measured number falls inside the stated range.
By their numbers in this assay, from the lowest: compounds 3 and 2 (each within the scatter of the next); then compound 1.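

Within the data shown here, this is the first step that can be read at a single place: in this assay, 1-methyl-1-(trifluoromethyl)ethoxy in place of cyclohexyl on a carbonyl carbon gives a 1.8-fold lower number from compound 2 to compound 3 (0.26 log units; within the scatter). At this position, whose other neighbour on the carbonyl carbon is an amide-type nitrogen in a ring, a six-membered carbon ring leaves and an open group with oxygen and fluorine enters, yet the two compounds cannot be told apart, so in this pair the ring is not needed to keep inhibition in this range. No measured property of either group bears on this result.

The entering group brings its oxygen, its fluorine atoms and its loss of the ring in one step, and compound 1 differs from both compounds in more than one place, so the share of each part stays unresolved. A plain tert-butoxy group without fluorine, or an amine or a carboxylic acid carried on the same carbonyl carbon, would show how much of this position's latitude extends beyond the two groups seen here.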